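The source may report more compounds than this note shows. Statements on the series, on what has been measured and on what is new or still open speak of the compounds shown alone.

Working notes on the hydrazone series.

Compound 1 `COc1ccc(C(=O)N/N=C/C2=Cc3ccccc3OC2C)cc1` carries a methoxy-substituted benzoyl hydrazone on the shared core. In a toxicity assay on HEK-293T cells (Homo sapiens) for cytotoxicity, read by MTT assay, with a stated time of 72 h (a higher number here means a weaker inhibitor, a lower number a stronger inhibitor), compound 1 gives "not determined" (no result reported), so it stands without a number of its own. The closest measured relative is compound 2 `CC1Oc2ccccc2C=C1/C=N/NC(=O)c1ccc(O)cc1`, which bears a free phenol in place of the methyl ether; in this assay compound 2 gives 48800 nM, a weak effect. For the measured compounds named here, that single value is the only anchor for the series so far.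

Compound 3 `COc1ccc(C(=O)N/N=C/C2=Cc3ccccc3OC2c2ccccc2)cc1` is the next member to be measured. Its relation to compound 1 is phenyl in place of methyl on a saturated ring carbon. Going by the values given here, no measured pair isolates this change, so its size and direction can only be guessed. Given how weak compound 2 is, any shift for compound 3 is as likely to stay within the scatter as to move beyond it, and a modest move toward stronger cytotoxicity is the more plausible side. Compound 3 is therefore expected to give about 30000 nM, within a range of 8000 nM to 100000 nM, with a real chance that only a limit is reported.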

Compound 3, half-maximal inhibitory concentration: 90700 nM
Beside the measured number, compound 3's estimate is 3.0-fold (0.48 log units) below it, and the stated range covers the measured number.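

No step can be read from compound 1 to compound 3: in this assay compound 1 gives "not determined" (no result reported) and leaves compound 3, at 90700 nM, without a partner for comparison. No supporting data bear on this result. From the compounds shown here alone, the effect of phenyl in place of methyl on a saturated ring carbon remains open.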